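Expected effect of a thiophene for methoxyphenyl exchange

The source may hold more compounds than are shown below. What is called first, only, known or untested is meant among the compounds shown, and "the series" means these compounds.

Compound 1 `Oc1c(C2OCCc3ccccc32)ccc2cccnc12` — 1.3 ug/mL
Compound 2 `COc1ccc(C(c2ccc3cccnc3c2O)c2ccc3cccnc3c2O)cc1` — < 0.3 ug/mL

In a functional assay on KB cells (Homo sapiens) for antiproliferative activity (on this read-out higher numbers stand for weaker inhibition and lower numbers for stronger inhibition), compound 1 gives 1.3 ug/mL. For compound 2 the recorded result is only a limit of the assay, < 0.3 ug/mL, as noted in the limit of < 0.3 ug/mL in this assay, at which 1 of the 2 values shown sits. Compound 3 `Oc1c(C(c2cccs2)c2ccc3cccnc3c2O)ccc2cccnc12` is not yet measured; it differs from compound 2 by thiophen-2-yl in place of 4-methoxyphenyl on a saturated chain carbon bound to two aromatic carbons. Among the measured compounds shown here, no measured pair spans this change, so no step size is known. In this assay a shift no larger than the scatter is expected, a step of a number no lower from compound 2 to compound 3 (the limit leaves the size open). Compound 3 is therefore estimated at 0.3 ug/mL, within 0.05 ug/mL to 1.5 ug/mL.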

Compound 3, half-maximal inhibitory concentration: < 0.3 ug/mL
Compound 3 was reported as a limit; the forecaster's own chance of this, stated with the estimate: 50%; the middle value lies on the limit itself.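

Compound 2 and compound 3 are both recorded only as limits of the assay, so no step between them can be read: the limit of < 0.3 ug/mL in this assay, at which 2 of the 3 values shown sit.

As far as these compounds go, whether thiophen-2-yl in place of 4-methoxyphenyl shifts the inhibition at all, and by how much, stays open.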